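The source may hold more compounds than are shown below. What is called first, only, known or untested is meant among the compounds shown, and "the series" means these compounds.

Measured in an assay on isolated protein for inhibition of leukotriene B4 receptor 1 (Homo sapiens), tested at 10 uM; a lower number here means less inhibition, a higher number more inhibition at the concentration tested (going by the name of the read-out):
compound 1, `CCCCCCc1cc(C(C)=O)c(O)cc1OCCCCC#N`: 51%
compound 2, `CC(=O)c1cc(C=O)c(OCCCCC#N)cc1O`: 6%
compound 3, `C=CCc1cc(C(C)=O)c(O)cc1OCCCC#N`: 47%

Compound 3 stands second highest of the three numbers in this assay. Its nearest neighbour is compound 1, whose number lies within the scatter of that of compound 3; compound 2 lies furthest away, below it and beyond the scatter. For the measured compounds named here, the one step with a single change, a number 45 percentage points lower from compound 1 to compound 2 (beyond the scatter), is large, but it concerns formyl in place of hexyl on an aromatic carbon and does not bear on the chain ending in the nitrile.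

Compound 4 is `C=CCc1cc(C(C)=O)c(O)cc1OCCCCCCCC#N`. It differs from compound 3 in this way: 4-cyanobutyl in place of cyano on a saturated chain carbon, three bonds along the chain from an oxygen on an aromatic ring. Going by the values given here, compounds 1 and 3 differ at two places, one of them the length of this chain, and their values lie within the scatter of each other; no single step on this chain has been measured. The expectation is therefore a step of no size beyond the scatter, a number 1 percentage points higher from compound 3 to compound 4 (within the scatter). Compound 4 is estimated at 48%, within 28% to 68%.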

Compound 4, a percentage reported as inhibition, at one concentration (the size of the read-out at that concentration, not a potency): 88%
For compound 4 the middle estimate is 40 percentage points below the measured one; measured number above the stated range.
By their numbers in this assay, from the lowest: compound 2; then compounds 3 and 1 (each within the scatter of the next); then compound 4.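

In this assay the chain ending in the nitrile proves sensitive to length: a number 41 percentage points higher from compound 3 to compound 4 (beyond the scatter) with 4-cyanobutyl in place of cyano on a saturated chain carbon, three bonds along the chain from an oxygen on an aromatic ring. For the compounds shown here, this is the only single step on this chain, and compound 1 and compound 3, which differ at two places, could not isolate the effect of its length. Nothing available accounts for the size of this step.

As far as these compounds go, whether the number keeps rising with a longer chain, or how it behaves at lengths between those of compound 3 and compound 4, stays open. Also open, from the compounds shown here alone, is whether a carboxylic acid or an amine in place of the nitrile would keep the number of compound 4 at 88% in this assay.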